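Piperazine chain variation on the shared core: cytotoxicity notes

The compounds below may be only part of what the source reports. "The series", "measured", "known", "first", "only" and "open" are said of these compounds alone.

Measured compounds:
compound 1 `CN1CCN(CCCCCn2c3c(c4ccccc42)C(=O)c2c[n+]([O-])c4ccccc4c2C3=O)CC1`, 1640 nM
compound 2 `O=C1c2c[n+]([O-])c3ccccc3c2C(=O)c2c1c1ccccc1n2Cc1cn(CC(O)CO)nn1`, 1070 nM
compound 3 `CC1(C)OC[C@H](Cn2cc(Cn3c4c(c5ccccc53)C(=O)c3c[n+]([O-])c5ccccc5c3C4=O)nn2)O1`, 470 nM

All three were read in a toxicity assay on L02 cells (Homo sapiens) for cytotoxicity, read by MTT assay, with a stated time of 72 h; on this read-out higher numbers stand for weaker inhibition and lower numbers for stronger inhibition. Compound 1 holds the highest number of the three; compound 2 sits within the scatter of it, as a 1.5-fold lower number from compound 1 to compound 2 (0.19 log units; within the scatter) shows, while compound 3 lies beyond it, a 2.3-fold lower number from compound 2 to compound 3 (0.36 log units; beyond the scatter) adding a modest further lowering. Compound 3 therefore gives the lowest number of the set.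

Compound 4 `CCCCN1CCN(CCCCn2c3c(c4ccccc42)C(=O)c2c[n+]([O-])c4ccccc4c2C3=O)CC1` is not yet measured. It differs from compound 1 by 4-butylpiperazin-1-yl in place of (4-methylpiperazin-1-yl)methyl on a saturated chain carbon, four bonds along the chain from an aromatic nitrogen. Both known steps rework the substituent on the aromatic nitrogen, but neither touches a piperazine or its alkyl group, so they bear only loosely on this change; what they show is that the chain region can be altered with changes that range from within the scatter to modest. Going by the values given here, no step in the set reaches a large size. For compound 4 in this assay a step near the scatter is expected, a 1.3-fold lower number from compound 1 to compound 4 (0.10 log units; within the scatter), with no clear direction. Compound 4 is estimated at 1300 nM, within 500 nM to 3500 nM.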

Compound 4, half-maximal inhibitory concentration: 5690 nM
Estimate against measurement, compound 4: 4.4-fold (0.64 log units) below; measured number above the stated range.
By their numbers in this assay, from the lowest: compound 3; then compounds 2 and 1 (each within the scatter of the next); then compound 4.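

In this assay, going by these compounds alone, a 3.5-fold higher number from compound 1 to compound 4 (0.54 log units; beyond the scatter) is the first step in the set that goes toward a higher number beyond the scatter, so changes at the piperazine-bearing end of the substituent are not neutral on this read-out. The step replaces (4-methylpiperazin-1-yl)methyl with 4-butylpiperazin-1-yl, which alters the alkyl group on the piperazine and the length of the chain together, and this single pair cannot assign the rise to either alteration. No measurement at hand accounts for the rise.

Still open, going by these compounds, is how the number responds when the alkyl group on the piperazine and the chain length are varied separately, for example a 4-methylpiperazin-1-yl group on the chain of compound 4. Also open, on these data alone, is how an unsubstituted piperazine, a 4-ethylpiperazin-1-yl group or a morpholine at the chain end would read.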